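Swapping chloro for methoxy on the phenyl ring

A few compounds are considered here, and "the series" means these few. Any claim that something is new, unique, unknown or untested is made for them only; others in the source may bear on it.

In a functional assay on HCT-116 cells (Homo sapiens) for antiproliferative activity, read by MTT assay, with a stated time of 72 h (on this read-out higher numbers stand for weaker inhibition and lower numbers for stronger inhibition), compound 1 `NC1=NC2(CCSCC2)N(OCCCOc2ccccc2Br)C(N)=N1` gives 1 nM, while compound 2 `NC1=NC2(CCSCC2)N(OCCCOc2ccc(Cl)cc2)C(N)=N1` gives 10 nM, the higher of the two numbers and so the weaker inhibition. Compound 3 `COc1ccc(OCCCON2C(N)=NC(N)=NC23CCSCC3)cc1` differs from compound 2 at one place: methoxy in place of chloro on an aromatic carbon, with methoxy in place of chloro on an aromatic carbon. Going by the values given here, the only measured step, a 10-fold higher number from compound 1 to compound 2 (1.00 log units; beyond the scatter), was modest and involved a different change, so it offers only loose guidance. The expected step is a 1.2-fold higher number from compound 2 to compound 3 (0.08 log units; within the scatter), with no shift beyond the scatter anticipated. Compound 3 is estimated at 12 nM, within a range of 4 nM to 40 nM.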

Compound 3, half-maximal inhibitory concentration: 70 nM
Compound 3: middle estimate off by 5.8-fold (0.77 log units), on the low side, outside the stated range (above it).
By their numbers in this assay, from the lowest: compound 1; then compound 2; then compound 3.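

On an aromatic ring, para to a large group, changing chloro to methoxy is not a neutral swap: the result is a 7.0-fold higher number from compound 2 to compound 3 (0.85 log units; beyond the scatter) and so weaker inhibition. Replacing 2-bromophenyl with 4-methoxyphenyl gives a 70-fold higher number from compound 1 to compound 3 (1.85 log units; beyond the scatter) and is the largest step among these compounds. Nothing available here explains why the methoxy compound inhibits less strongly.

From the compounds shown here alone, whether an amine or a fluoro group at this same place would stay close to compound 2 remains open. So does the effect of a longer chain between the oxygen atoms.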